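A Trifluoromethyl Aniline Tested Against the Shared Quinazoline Core

This account rests on a few compounds, and the source may have more. Where it says the series, first, only, none or still open, it means among the compounds named here.

Three compounds share one core and differ only in the aryl group on the ring nitrogen. In a functional assay on A-431 cells (Homo sapiens) for antiproliferative activity, read by MTT assay, with a stated time of 72 h (a lower number here means a stronger inhibitor, a higher number a weaker inhibitor), compound 1 `COc1cc2ncnc(Nc3ccc(F)c(Cl)c3)c2cc1OCCCCC(=O)Nc1ccc(S(N)(=O)=O)cc1` gives 5020 nM, compound 2 `COc1ccc(Nc2ncnc3cc(OC)c(OCCCCC(=O)Nc4ccc(S(N)(=O)=O)cc4)cc23)cc1OC` gives 35400 nM, and compound 3 `COc1ccccc1Nc1ncnc2cc(OC)c(OCCCCC(=O)Nc3ccc(S(N)(=O)=O)cc3)cc12` gives 24200 nM. Compound 3 thus sits second highest of the three, the nearer step being a 1.5-fold lower number from compound 2 to compound 3 (0.17 log units; within the scatter) and the further step being a 4.8-fold higher number from compound 1 to compound 3 (0.68 log units; beyond the scatter). Compound 4 `COc1cc2ncnc(Nc3ccc(C(F)(F)F)cc3)c2cc1OCCCCC(=O)Nc1ccc(S(N)(=O)=O)cc1` carries 4-(trifluoromethyl)phenyl in place of 2-methoxyphenyl on a nitrogen on an aromatic ring. The swaps that bear on it are a 7.1-fold higher number from compound 1 to compound 2 (0.85 log units; beyond the scatter) and a 4.8-fold higher number from compound 1 to compound 3 (0.68 log units; beyond the scatter), both modest. With compound 1 as the low mark, compound 4 is expected to move down from compound 3 by a 2.4-fold lower number from compound 3 to compound 4 (0.38 log units; beyond the scatter), a modest step. The estimate for compound 4 in this assay is 10000 nM, within 3000 nM to 35000 nM.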

Compound 4, half-maximal inhibitory concentration: 16900 nM
The estimate for compound 4 lay 1.7-fold (0.23 log units) below the measured number; low and high end bracket the measured number.
By their numbers in this assay, from the lowest: compound 1; then compounds 4, 3 and 2 (each within the scatter of the next, the first and the last beyond it).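

Replacing 2-methoxyphenyl with 4-(trifluoromethyl)phenyl on the nitrogen does not separate the two compounds in this assay (a 1.4-fold lower number from compound 3 to compound 4 (0.16 log units; within the scatter)). The new group does stand apart from 3,4-dimethoxyphenyl (a 2.1-fold lower number from compound 2 to compound 4 (0.32 log units; beyond the scatter)), but a fluorinated aryl group alone does not match 3-chloro-4-fluorophenyl (a 3.4-fold higher number from compound 1 to compound 4 (0.53 log units; beyond the scatter)). Nothing measured here explains these differences. The compounds shown leave open whether a lone chlorine, a nitrile or an amine on the aryl ring would come closer to compound 1. They also leave open whether moving the trifluoromethyl group around that ring would change the number.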